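Swapping methoxy for fluoro on a sulfanyl-linked phenyl ring

The source may report more compounds than this note shows. Statements on the series, on what has been measured and on what is new or still open speak of the compounds shown alone.

Compound 1, `COc1ccc(CNc2nc3cc(N)cc(N)c3nc2-c2ccccc2)cc1`: 41700 nM
Compound 2, `COc1ccc(Sc2nc3cc(N)cc(N)c3nc2-c2ccccc2)cc1`: limit only

In a functional assay on SNB-19 cells (Homo sapiens) for inhibition, read by sulforhodamine B assay, with a stated time of 48 h (a lower number here means a stronger inhibitor of growth, a higher number a weaker inhibitor of growth), compound 1 gives 41700 nM. For compound 2 the reading is a limit of the assay rather than a number, shown as < 100000 nM; this is the point noted as the limit of < 100000 nM in this assay, at which 1 of the 2 values shown sits. Among the compounds with values here, compound 2 and compound 1 share their core and differ in the link to the outer ring, but no step between them is given, so only their two readings stand.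

Compound 3, `Nc1cc(N)c2nc(-c3ccccc3)c(Sc3ccc(F)cc3)nc2c1`, keeps the sulfur link of compound 2 and changes the outer ring: fluoro in place of methoxy on an aromatic carbon. Within the data shown here, with no measured step of this kind among the compounds, the change from compound 2 is expected to move the result by no more than the scatter, in either direction, as in a step that the limit leaves unreadable from compound 2 to compound 3. In this assay compound 3 is therefore estimated at 60000 nM, within 20000 nM to 150000 nM.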

Compound 3, concentration for 50% growth inhibition: 20000 nM
The estimate for compound 3 lay 3.0-fold (0.48 log units) above the measured number; measured number inside the range.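

No step can be read from compound 2 to compound 3, since compound 2 stands at a limit of the assay rather than at a number: the limit of < 100000 nM in this assay, at which 1 of the 3 values shown sits.

The compounds shown leave open what fluoro in place of methoxy does in this assay when both readings are numbers.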